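The source may report more compounds than this note shows. Statements on the series, on what has been measured and on what is new or still open speak of the compounds shown alone.

Notes on the series. Compound 2 `CCC(=O)N[C@@H]1CCCc2c1cncc2N1Cc2cc(Cl)ccc2C1=O` gives 28 nM in an assay on cells for inhibition of cytochrome P450 11B2, mitochondrial (Homo sapiens), read by HTRF (on this read-out lower numbers stand for stronger inhibition and higher numbers for weaker inhibition), the second highest of the three measured numbers. Compound 1 `CCS(=O)(=O)N[C@@H]1CCCc2c1cncc2N1Cc2cc(Cl)ccc2C1=O` gives 40 nM in this assay, and compound 3 `CCS(=O)(=O)N1CC2(CN(c3cncc(N4C(=O)c5ccc(Cl)cc5C4(C)C)c3)C2)C1`, built on a different core, gives 16 nM; the gaps from compound 2 to each of these lie within the scatter, so no order is read into them. Compound 4 `CS(=O)(=O)N[C@@H]1CCCc2c1cncc2N1Cc2cc(Cl)ccc2C1=O` differs from compound 2 as follows: methylsulfonyl in place of propanoyl on an amine nitrogen. For the measured compounds named here, the only measured step that bears on this change is a 1.4-fold lower number from compound 1 to compound 2 (0.15 log units; within the scatter), which exchanges an ethylsulfonyl for the propanoyl on the same amine nitrogen and stays within the scatter; compound 4 runs that exchange back, but with a methylsulfonyl rather than the ethylsulfonyl. Nothing measured separates the methyl from the ethyl sulfonamide, so no step beyond the scatter is expected in this assay. For compound 4 the expected step is a 1.4-fold higher number from compound 2 to compound 4 (0.15 log units; within the scatter). That expectation points toward the number of compound 1 at 40 nM. Compound 4 is therefore estimated at 40 nM, with a range of 18 nM to 90 nM.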

Compound 4, half-maximal inhibitory concentration: 998 nM
The estimate for compound 4 lay 25-fold (1.40 log units) below the measured number; measured number above the stated range.
By their numbers in this assay, from the lowest: compounds 3, 2 and 1 (each within the scatter of the next, the first and the last beyond it); then compound 4.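

In this assay, the amine nitrogen proves far less tolerant than compound 1 and compound 2 suggested, with methylsulfonyl in place of propanoyl giving a 36-fold higher number from compound 2 to compound 4 (1.55 log units; beyond the scatter). The sulfonyl group alone does not account for the loss, since the ethylsulfonyl of compound 1 and the propanoyl of compound 2 lie within the scatter of each other. Trimming the ethylsulfonyl to methylsulfonyl gives a 25-fold higher number from compound 1 to compound 4 (1.40 log units; beyond the scatter), so the terminal methyl on this chain carries much of the inhibition seen in compound 1, though nothing at hand gives a reason for this.

Still open, as far as these compounds go, is whether an acetyl on the same nitrogen would show a similar loss on the amide side. A propylsulfonyl or other longer chain could also show whether the number keeps improving with length or levels off.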